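Fluorine on the phenyl ring of a benzothiophene alkyne

The compounds below may be only part of what the source reports. "The series", "measured", "known", "first", "only" and "open" are said of these compounds alone.

Of the compounds shown here, two have been measured so far. Compound 1 `COC(=O)c1sc2cc(OC)ccc2c1C#Cc1ccccc1F` gives 10300 nM in a functional assay on cells (CNS cell, Homo sapiens) for cytotoxicity, read by sulforhodamine B assay, with a stated time of 48 h; a higher number here means a weaker inhibitor of growth, a lower number a stronger inhibitor of growth. For the measured compounds named here, compound 2 `COC(=O)c1sc2ccccc2c1C#Cc1ccccc1` gives 58900 nM in this assay, the highest of the two numbers; its nearest neighbour is compound 1, whose number sits well beyond the scatter below it, although compound 1 differs from compound 2 in more than one place, so no single step between them can be read off. Compound 3 `COC(=O)c1sc2ccccc2c1C#Cc1ccccc1F` is the next compound to be measured. It differs from compound 2 only as follows: fluoro in place of hydrogen on an aromatic carbon. Since compound 1 carries this same fluoro and a lower number, a modest move downward is expected, but it cannot be said how much of the gap belongs to the fluoro alone. Compound 3 is therefore expected to give 28000 nM in this assay, within 9000 nM to 80000 nM, which would mean an expected step of a 2.1-fold lower number from compound 2 to compound 3 (0.32 log units; beyond the scatter).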

Compound 3, concentration for 50% growth inhibition: 30200 nM
Beside the measured number, compound 3's estimate is 1.1-fold (0.03 log units) below it, and the stated range covers the measured number.
By their numbers in this assay, from the lowest: compound 1; then compounds 3 and 2 (each within the scatter of the next).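

In this assay, fluoro in place of hydrogen on the phenyl ring, ortho to a large group, gives a 2.0-fold lower number from compound 2 to compound 3 (0.29 log units; within the scatter), so on the unsubstituted core this change does not separate the two compounds. For the compounds shown here, the methoxy place on the core does register: hydrogen in place of methoxy gives a 2.9-fold higher number from compound 1 to compound 3 (0.47 log units; beyond the scatter), the only step here that clears the scatter, and it is modest. Nothing available accounts for either step.

The compounds shown leave open whether methoxy would give a similar step on a core bearing the plain phenyl ring, since it has been compared only with the 2-fluorophenyl group present. They also leave open how an amine at the methoxy place, or a carboxylic acid in place of the methyl ester, would read.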